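A few compounds are considered here, and "the series" means these few. Any claim that something is new, unique, unknown or untested is made for them only; others in the source may bear on it.

Compound 1 `COc1ccc(/C=C/C(=O)/C=C/c2nc3ccccc3n2C)cc1O`: 3600 nM
Compound 2 `COc1ccc(/C=C/C(=O)/C=C/c2nc3cc(C)ccc3n2C)cc1O`: 3600 nM
Compound 3 `COc1ccc(/C=C/C(=O)/C=C/c2nc3c(C)cccc3n2C)cc1O`: not yet measured

In a functional assay on MCF7 cells (Homo sapiens) for cytotoxicity, read by MTT assay, with a stated time of 48 h (on this read-out lower numbers stand for stronger inhibition and higher numbers for weaker inhibition), compound 1 gives 3600 nM, level with compound 2 at 3600 nM. Compound 3 differs from compound 1 by methyl in place of hydrogen on an aromatic carbon. Among the compounds with values here, only one measured step bears on this change: the same replacement at a different aromatic carbon, no change at the digits printed from compound 1 to compound 2 (within the scatter). Within the data shown here, a single case is thin evidence, and no measurement yet covers this carbon. Even so, no step beyond the scatter is expected in this assay. The expected change is no change at the digits printed from compound 1 to compound 3 (within the scatter). Compound 3 is estimated at 3600 nM, with an expected range of 1500 nM to 8500 nM.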

Compound 3, half-maximal inhibitory concentration: 7400 nM
Estimate against measurement, compound 3: 2.1-fold (0.31 log units) below; the measured number falls inside the stated range.
By their numbers in this assay, from the lowest: compounds 1 and 2 (each within the scatter of the next); then compound 3.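

Methyl in place of hydrogen on this aromatic carbon, ortho to a fused ring, gives a 2.1-fold higher number from compound 1 to compound 3 (0.31 log units; beyond the scatter) in this assay and so does not leave the number untouched, while the same replacement at a different aromatic carbon gave no change at the digits printed from compound 1 to compound 2 (within the scatter) in that comparison. The effect of this change therefore depends on which aromatic carbon carries the methyl, at least across these two modest steps. Nothing available explains the difference. From the compounds shown here alone, whether ethyl, methoxy, chlorine or an amine on this carbon would move the number further, or in the opposite direction, remains open.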